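The compounds below may be only part of what the source reports. "The series", "measured", "known", "first", "only" and "open" are said of these compounds alone.

The series rests on one shared core, carried by compound 1 `CC1(C)C=C(n2ccccc2=O)c2cc(C(=O)c3ccc(O)cc3)ccc2O1`, compound 2 `CC1(C)C=C(n2ccccc2=O)c2cc(C=O)ccc2O1` and compound 3 `CC1(C)C=C(n2ccccc2=O)c2cc(O)ccc2O1`, which differ only in the group held on one aromatic carbon. In a functional assay (aorta) with Rattus norvegicus as the target (a higher number here means a more potent compound, by a factor of ten per unit of this negative logarithm, a lower number a less potent compound), compound 1 gives 6.65, compound 2 gives 6.91 and compound 3 gives 5.44. Compound 3 stands lowest of the three: the value falls a number 1.21 log units lower from compound 1 to compound 3 (beyond the scatter) and a number 1.47 log units lower from compound 2 to compound 3 (beyond the scatter), both beyond the scatter, whereas the two upper values sit only a number 0.26 log units higher from compound 1 to compound 2 (within the scatter), within it.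

The next compound is compound 4 `CC1(C)C=C(n2ccccc2=O)c2cc(Br)ccc2O1`. The change from compound 3 to compound 4 is bromo in place of hydroxy on an aromatic carbon.

Going by the values given here, two measured steps bear on this change, since both end at compound 3 and both put hydroxy onto that carbon: the drop a number 1.21 log units lower from compound 1 to compound 3 (beyond the scatter) and the drop a number 1.47 log units lower from compound 2 to compound 3 (beyond the scatter). Both were large, so the hydroxy compound is the weak point of the set. Among the compounds with values here, no measured step exchanges hydroxy for bromo, and bromo resembles neither of the groups already tried, so the size of the step is uncertain. Still, compound 4 is expected to move upward, by about a number 0.96 log units higher from compound 3 to compound 4 (beyond the scatter). Compound 4 is therefore estimated at 6.4, with a range from 5.7 to 7.1.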

Compound 4, logarithm of the reciprocal of the active concentration, log(1/C): 7.84
For compound 4 the middle estimate is 1.44 log units below the measured one; the whole stated range lies below it.
By their numbers in this assay, from the lowest: compound 3; then compounds 1 and 2 (each within the scatter of the next); then compound 4.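

In this assay the bromo group gives compound 4 the highest value of the set on this aromatic carbon, standing a number 2.40 log units higher from compound 3 to compound 4 (beyond the scatter) and also a number 0.93 log units higher from compound 2 to compound 4 (beyond the scatter) and a number 1.19 log units higher from compound 1 to compound 4 (beyond the scatter) in the same series. The earlier compounds shown here ranked two carbonyl-bearing groups above hydroxy, but compound 4 shows that neither a carbonyl nor any hydrogen-bond donor or acceptor is needed on this carbon for the best value here, and that exchanging one single heavy atom for another at this place can shift the value by a large step. The data shown offer no measurement that accounts for this rise.

As far as these compounds go, it remains open whether the gain comes from the presence of bromine itself or chiefly from the loss of hydroxy, and a plain hydrogen on this carbon would help to separate the two. From the compounds shown here alone, how a chloro, an iodo, a nitrile, an amine or a carboxylic acid would stand against bromo at this place also remains unknown, as does whether the gain holds in any setting other than this aorta read-out.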